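This account rests on a few compounds, and the source may have more. Where it says the series, first, only, none or still open, it means among the compounds named here.

Of the compounds shown here, three sharing one core have been measured in an assay on isolated protein for displacement of a labelled ligand from corticotropin-releasing factor receptor 1 (Homo sapiens); on this read-out higher numbers stand for weaker inhibition and lower numbers for stronger inhibition. Compound 1 `CCCCC(CC)Nc1nc(C)nc2c(-c3ccc(Cl)cc3Cl)c(C)nn12` gives 1.6 nM. Compound 2 `CCCC(CCC)Nc1nc(C)nc2c(-c3ccc(Cl)cc3Cl)c(C)nn12` gives 1.6 nM, level with compound 1 at the digits shown, and together these two are the highest of the three numbers. Compound 3 `CCCN(CCC)c1nc(C)nc2c(-c3ccc(Cl)cc3Cl)c(C)nn12`, which carries a dipropylamino group where the other two carry a branched alkylamino group, gives 0.6 nM; the step of a 2.7-fold lower number from compound 2 to compound 3 (0.43 log units; beyond the scatter) is modest, and the step of a 2.7-fold lower number from compound 1 to compound 3 (0.43 log units; beyond the scatter) is the same size.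

Compound 4 `CCC(COC)Nc1nc(C)nc2c(-c3ccc(Cl)cc3Cl)c(C)nn12` has not yet been measured. It differs from compound 2 at one place: 1-(methoxymethyl)propyl in place of 1-propylbutyl on a nitrogen on an aromatic ring. Within the data shown here, one measured step bears on this change: no change at the digits printed from compound 1 to compound 2 (within the scatter), where one branched chain replaced another on the same nitrogen without moving the number. Among the measured compounds shown here, no measured compound, however, carries an oxygen in this chain, so the data show nothing about the hydrogen-bond acceptor that enters. Given the flat step from compound 1 to compound 2 in this assay, a slight weakening or no change beyond the scatter is expected for compound 4. The expected step is a 1.9-fold higher number from compound 2 to compound 4 (0.27 log units; within the scatter). Compound 4 is estimated at 3 nM, with a range from 1 nM to 10 nM.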

Compound 4, inhibition constant: 1.9 nM
Compound 4: the middle estimate sits 1.6-fold (0.20 log units) above what was measured; measured number inside the range.
By their numbers in this assay, from the lowest: compound 3; then compounds 1, 2 and 4 (each within the scatter of the next).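

The chain on the nitrogen tolerates an oxygen in this assay: with 1-(methoxymethyl)propyl in place of 1-propylbutyl, the count of hydrogen-bond acceptors in the chain goes from 0 to 1, yet the result is a 1.2-fold higher number from compound 2 to compound 4 (0.07 log units; within the scatter). The same holds against the other branched chain, with methoxy in place of propyl giving a 1.2-fold higher number from compound 1 to compound 4 (0.07 log units; within the scatter), so the tolerance seen earlier among all-carbon branched chains now extends to a chain containing an ether oxygen. Compound 3 remains apart from this group, as the comparison with the new compound gives a 3.2-fold higher number from compound 3 to compound 4 (0.50 log units; beyond the scatter), a modest step beyond the scatter.

Nothing available explains why the oxygen leaves the number within the scatter, or whether the acceptor takes part in binding at all. Still open, as far as these compounds go, is whether a hydroxyl or an amine at the end of this chain, or a longer ether chain, would also stay within the scatter, and whether a methoxy group on the propyl chains of compound 3 would be accepted in the same way.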